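The source may report more compounds than this note shows. Statements on the series, on what has been measured and on what is new or still open speak of the compounds shown alone.

Working notes on the series: in a functional assay on MIA PaCa-2 cells (Homo sapiens) for inhibition, read by MTT assay, with a stated time of 48 h, tested at 10 uM (a lower number here means less inhibition of growth, a higher number more inhibition of growth at the concentration tested), compound 1 `COc1ccc(COc2cc(O)c3c(=O)cc(C)oc3c2[C@H]2CCN(C)C[C@H]2O)cc1` gives 15% while compound 2 `Cc1cc(=O)c2c(O)c(CN3CCCC3CO)c(O)c([C@H]3CCN(C)C[C@H]3O)c2o1` gives 13% and compound 3 `Cc1cc(=O)c2c(O)c(CN3CCC(Cc4ccccc4)CC3)c(O)c([C@H]3CCN(C)C[C@H]3O)c2o1` gives 18% so all three readings lie within the scatter of each other. Among the compounds with values here, compound 2 therefore stands level with both other compounds, and no measured pair differs in one place only. The next compound to be read is compound 4 `Cc1cc(=O)c2c(O)c(CN(C(C)C)C(C)C)c(O)c([C@H]3CCN(C)C[C@H]3O)c2o1` and its change from compound 2 is diisopropylamino in place of 2-(hydroxymethyl)pyrrolidin-1-yl on a saturated chain carbon bound to an aromatic carbon with diisopropylamino in place of 2-(hydroxymethyl)pyrrolidin-1-yl on a saturated chain carbon bound to an aromatic carbon. No direct measurement of this change exists. Within the data shown here, the only indirect guide is that compound 3, which also carries a different group at this place, reads 18% and stays within the scatter of compound 2 in this assay and so no step beyond the scatter is expected, in either direction. The expected step is a number 2 percentage points higher from compound 2 to compound 4 (within the scatter) and this estimate remains inside the scatter. For compound 4 the estimated value is 15% with an expected range from 5% to 27% in this assay when the measurement is made.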

Compound 4, percent growth inhibition at one concentration: 11%
Compound 4: middle estimate off by 4 percentage points, on the high side; measured number inside the range.
By their numbers in this assay, from the lowest: compounds 4, 2, 1 and 3 (each within the scatter of the next).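

In this assay, the one-place step at this position, on a saturated chain carbon bound to an aromatic carbon, is a number 2 percentage points lower from compound 2 to compound 4 (within the scatter), so replacing 2-(hydroxymethyl)pyrrolidin-1-yl with diisopropylamino leaves the reading level. This exchange gives up the ring and the hydrogen-bond donor of the leaving group while the heavy-atom count stays the same, and neither loss shifts growth inhibition beyond the scatter at the single concentration tested. No measurement at hand bears on why the reading stays level.

On these data alone, it remains open whether any group at this position can move the reading beyond the scatter, since this one step covers only two tertiary amines of equal heavy-atom count. A carboxylic acid or a primary amine on the same chain carbon would show whether the position tolerates a group of a different kind, and full concentration-response readings could reveal differences that a single concentration does not resolve.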